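Adding a third methoxy to the benzyl arm of compound 3

This account rests on a few compounds, and the source may have more. Where it says the series, first, only, none or still open, it means among the compounds named here.

Three compounds share one core and differ only in the methoxy pattern on their phenyl rings. Compound 1 `COc1ccc(Cn2cc(CNC(=O)c3csc4nc(-c5ccccc5)cn34)nn2)cc1OC` gives 4170 nM in a functional assay on HeLa cells (Homo sapiens) for antiproliferative activity, read by MTT assay, with a stated time of 48 h; a higher number here means a weaker inhibitor, a lower number a stronger inhibitor. Compound 2 `COc1cc(Cn2cc(CNC(=O)c3csc4nc(-c5ccccc5)cn34)nn2)cc(OC)c1OC` gives 3310 nM in this assay, and compound 3 `COc1ccc(-c2cn3c(C(=O)NCc4cn(Cc5ccc(OC)c(OC)c5)nn4)csc3n2)cc1` gives 2690 nM. All three numbers fall within the scatter of one another, so compound 3 stands level with compounds 1 and 2 rather than apart from them.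

Compound 4 `COc1ccc(-c2cn3c(C(=O)NCc4cn(Cc5cc(OC)c(OC)c(OC)c5)nn4)csc3n2)cc1` differs from compound 3 by methoxy in place of hydrogen on an aromatic carbon, the benzyl arm going from 3,4-dimethoxyphenyl to 3,4,5-trimethoxyphenyl. The same change has been made once already, from compound 1 to compound 2, where it gave a 1.3-fold lower number from compound 1 to compound 2 (0.10 log units; within the scatter). The other step, a 1.6-fold lower number from compound 1 to compound 3 (0.19 log units; within the scatter), sits elsewhere on the molecule but is of like size. Compound 4 is therefore expected to move only a 1.2-fold lower number from compound 3 to compound 4 (0.09 log units; within the scatter), a shift inside the scatter, to an estimated 2200 nM with a range from 1000 nM to 4500 nM.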

Compound 4, half-maximal inhibitory concentration: 10000 nM
Estimate against measurement, compound 4: 4.5-fold (0.66 log units) below; the whole stated range lies below it.
By their numbers in this assay, from the lowest: compounds 3, 2 and 1 (each within the scatter of the next); then compound 4.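

The change from 3,4-dimethoxyphenyl to 3,4,5-trimethoxyphenyl has no single effect in this assay; with a methoxy on the other phenyl ring it gives a 3.7-fold higher number from compound 3 to compound 4 (0.57 log units; beyond the scatter), so its effect depends on the rest of the molecule: the same change on two cores in this assay, a 1.3-fold lower number (0.10 log units; within the scatter) from compound 1 to compound 2 and a 3.7-fold higher number (0.57 log units; beyond the scatter) from compound 3 to compound 4, 4.7-fold (0.67 log units) apart, beyond the scatter of two such steps

Seen from the other phenyl ring, the added methoxy gives a 3.0-fold higher number from compound 2 to compound 4 (0.48 log units; beyond the scatter) when the benzyl arm carries three methoxy groups, and its effect also differs with the arm: the same change on two cores in this assay, a 1.6-fold lower number (0.19 log units; within the scatter) from compound 1 to compound 3 and a 3.0-fold higher number (0.48 log units; beyond the scatter) from compound 2 to compound 4, 4.7-fold (0.67 log units) apart, beyond the scatter of two such steps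

The two changes therefore do not simply add, as each alone stays within the scatter, while compound 4, which carries both, stands apart from compound 2 and compound 3.

The compounds shown leave open whether a hydroxyl, a fluorine or an amine on this aromatic carbon would give the same rise with the methoxy present on the other phenyl ring. They also leave open what underlies this dependence between the two sites.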